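A few compounds are considered here, and "the series" means these few. Any claim that something is new, unique, unknown or untested is made for them only; others in the source may bear on it.

Measured in a functional assay on A-375 cells (Homo sapiens) for inhibition, read by CCK-8 assay, with a stated time of 72 h, tested at 8 uM; a lower number here means less inhibition of growth, a higher number more inhibition of growth at the concentration tested:
- Compound 1 `Nc1ccccc1NC(=O)/C=C/c1ccc(CSc2ccc(Cl)cc2)cc1`: 48.2%
- Compound 2 `Nc1ccccc1NC(=O)/C=C/c1ccc(CSc2ccc(C(F)(F)F)cn2)cc1`: 3.96%
- Compound 3 `Cc1ccc(SCc2ccc(/C=C/C(=O)Nc3ccccc3N)cc2)cc1`: 31.2%

Of these three, compound 3 is second highest, below compound 1 and above compound 2. The next compound, compound 4 `CC(C)(C)c1ccc(SCc2ccc(/C=C/C(=O)Nc3ccccc3N)cc2)cc1`, keeps the core of compound 3 and carries tert-butyl in place of methyl on an aromatic carbon, para to a large group (tert-butyl in place of methyl on an aromatic carbon).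

The nearest evidence comes from the same place on the same ring, where methyl replaces chloro: a number 17 percentage points lower from compound 1 to compound 3 (beyond the scatter). That step is modest. Exchanging the whole group on the sulfur gives a second modest step, a number 27.2 percentage points higher from compound 2 to compound 3 (beyond the scatter), and a large one, a number 44.2 percentage points lower from compound 1 to compound 2 (beyond the scatter). Among the measured compounds shown here, the read-out therefore moves with changes in this part of the molecule, but no measured compound carries tert-butyl, so the direction remains open. Only a small net shift is expected, with a wide margin on either side: the estimate is a number 2.8 percentage points higher from compound 3 to compound 4 (within the scatter). For compound 4 the expected value is 34%, with an estimated range from 12% to 56%.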

Compound 4, percent growth inhibition at one concentration: 35.5%
For compound 4 the middle estimate is 1.5 percentage points below the measured one, and the stated range covers the measured number.
By their numbers in this assay, from the lowest: compound 2; then compounds 3 and 4 (each within the scatter of the next); then compound 1.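

In this assay, tert-butyl in place of methyl on this aromatic carbon gives a number 4.3 percentage points higher from compound 3 to compound 4 (within the scatter), so a much larger alkyl group cannot be told apart from methyl here. Chloro at the same place remains separate from tert-butyl, with a number 12.7 percentage points lower from compound 1 to compound 4 (beyond the scatter), so among the three groups shown on this carbon, only chloro stands apart from the others. The 4-(tert-butyl)phenyl group on the sulfur also differs clearly from 5-(trifluoromethyl)pyridin-2-yl, with a number 31.5 percentage points higher from compound 2 to compound 4 (beyond the scatter), and no measurement at hand explains any of these steps.

The compounds shown leave open whether an amine or a carboxylic acid on this carbon would fall with methyl and tert-butyl, or nearer to chloro. They also leave open how a methoxy group or a longer alkyl chain would behave at this place.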